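This account rests on a few compounds, and the source may have more. Where it says the series, first, only, none or still open, it means among the compounds named here.

Measured compounds and values in an in vitro functional assay on cells for agonist activity at Bombesin receptor subtype-3 (Mus musculus), read by luminescence and calcium flux; a lower number here means that less compound is needed, a higher number that more compound is needed for the effect:
compound 1 `O=C(O)c1ccccc1-c1ccc(CCc2ncc(-c3ccccc3)[nH]2)cc1` — 872 nM
compound 2 `CC(C)(C)Cc1cnc(CCc2ccc(-c3ccccc3C(=O)O)cc2)[nH]1` — 6.3 nM
compound 3 `COc1cccc(Cc2cnc(CCc3ccc(-c4ccccc4C(=O)O)cc3)[nH]2)c1` — 79 nM

Compound 3 sits second highest of the three numbers in this assay, with an 11-fold lower number from compound 1 to compound 3 (1.04 log units; beyond the scatter) on one side and a 13-fold higher number from compound 2 to compound 3 (1.10 log units; beyond the scatter) on the other. Compound 4 `O=C(O)c1ccccc1-c1ccc(CCc2ncc(CCc3ccccc3)[nH]2)cc1` differs from compound 3 by benzyl in place of 3-methoxyphenyl on a saturated chain carbon bound to an aromatic carbon. Within the data shown here, two steps bear on it: an 11-fold lower number from compound 1 to compound 3 (1.04 log units; beyond the scatter) and a 13-fold higher number from compound 2 to compound 3 (1.10 log units; beyond the scatter), both large, and both show that what hangs on the saturated chain carbon bound to the aromatic carbon moves the number strongly. Among the measured compounds shown here, no measured pair removes a methoxy alone, so the direction for compound 4 is uncertain; a modest step, a 2.0-fold lower number from compound 3 to compound 4 (0.30 log units; within the scatter), is expected. Compound 4 is estimated at 40 nM, within 8 nM to 250 nM.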

Compound 4, half-maximal effective concentration: 174 nM
For compound 4 the middle estimate is 4.4-fold (0.64 log units) below the measured one; the range from low to high includes it.
By their numbers in this assay, from the lowest: compound 2; then compound 3; then compound 4; then compound 1.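

In the series, phenethyl in place of phenyl on the aromatic carbon lowers the number (a 5.0-fold lower number from compound 1 to compound 4 (0.70 log units; beyond the scatter)) in this assay, but the phenethyl compound remains far from the neopentyl compound (a 28-fold higher number from compound 2 to compound 4 (1.44 log units; beyond the scatter)). The change from 3-methoxybenzyl to phenethyl costs only a modest step (a 2.2-fold higher number from compound 3 to compound 4 (0.34 log units; beyond the scatter)), so neither aromatic side chain approaches neopentyl here.

This change alters the methoxy group and the chain together, so the compounds shown cannot separate the two. On these data alone, how a cyclohexylmethyl group or an amine on this chain would read remains open. No evidence bears on the cause of these steps.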